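The compounds below may be only part of what the source reports. "The series", "measured", "known", "first", "only" and "open" are said of these compounds alone.

Of the compounds shown here, two have been measured so far in a physicochemical assay for lipophilicity, read by LC-MS, using the shake flask method, in phosphate buffer, measured as octanol-water partition, with a stated time of 2 h, at pH 7.4 (on this read-out lower numbers stand for lower lipophilicity and higher numbers for higher lipophilicity), and their values are these.

Compound 1 `Cc1ccc(-c2cn(C[C@H]3O[C@H](CO)[C@@H](O)[C@H](O)[C@@H]3O)nn2)cc1` gives 0.23 
Compound 2 `OC[C@H]1O[C@H](Cn2cc(-c3cccc(Cl)c3)nn2)[C@@H](O)[C@@H](O)[C@@H]1O` gives 0.68 

Within the data shown here, compound 1 holds the lower of these two numbers, and compound 2 is the only neighbour available for comparison. Still unmeasured is compound 3 `OC[C@H]1O[C@H](Cn2cc(-c3ccc(C(F)(F)F)cc3)nn2)[C@@H](O)[C@@H](O)[C@@H]1O` which differs from compound 1 in a single place. The change is trifluoromethyl in place of methyl on an aromatic carbon or in words, trifluoromethyl in place of methyl on an aromatic carbon, para to a large group.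

Among the measured compounds shown here, only one measured step bears on this, a number 0.45 log units higher from compound 1 to compound 2 (beyond the scatter) and it too swaps one group for another on an aromatic carbon. It involves a different entering group and stands alone, so it serves as a rough guide only. A step of similar size in the same upward direction is expected here, estimated as a number 0.47 log units higher from compound 1 to compound 3 (beyond the scatter) on the strength of that single comparison. For compound 3 the expected value is 0.7 with an estimated range from 0.35 to 1.1 on this scale.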

Compound 3, distribution coefficient: 1.07
Beside the measured number, compound 3's estimate is 0.37 log units below it, within the range that was stated.
By their numbers in this assay, from the lowest: compound 1; then compound 2; then compound 3.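

Swapping methyl for trifluoromethyl on an aromatic carbon, para to a large group, gives a number 0.84 log units higher from compound 1 to compound 3 (beyond the scatter) in this assay, with the rest of the molecule unchanged. This is a cleaner reading of this position than the earlier step, which put 3-chlorophenyl in place of 4-methylphenyl and so changed both the group and where it sits, whereas here a group of 4 heavy atoms replaces one of 1 heavy atom at the same spot, and the number still moves beyond the scatter. Nothing measured here explains why the number rises with this particular swap.

As far as these compounds go, with only methyl and trifluoromethyl compared at this position, it remains open how other groups placed there would behave, such as a single chlorine atom, a methoxy group, an amine or a carboxylic acid. From the compounds shown here alone, it also remains open whether the same swap would give a step of similar size on a different core, since this one comparison rests on a single pair of compounds.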